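The compounds below may be only part of what the source reports. "The series", "measured", "known", "first", "only" and "open" are said of these compounds alone.

Three compounds share one core and differ only in the amine at the end of the side chain. Compound 1 `CN(CCC#N)C[C@H]1CN(c2ccc(-n3cc(-c4ccccn4)cn3)c(F)c2)C(=O)O1` shows > 400 ug/mL in an ADME assay on HEK293-A cells (Homo sapiens) for cytotoxicity, read by MTT assay, with a stated time of 48 h (a higher number here means a weaker inhibitor, a lower number a stronger inhibitor), which is a limit of the assay rather than a number. Compound 2 `CCN1CCN(C[C@H]2CN(c3ccc(-n4cc(-c5ccccn5)cn4)c(F)c3)C(=O)O2)CC1` gives 99 ug/mL in this assay. Compound 3 `O=C1O[C@@H](CN2CCCCC2)CN1c1ccc(-n2cc(-c3ccccn3)cn2)c(F)c1` shows > 400 ug/mL, again only a limit. Two of the three values therefore sit at the limit of > 400 ug/mL in this assay, at which 2 of the 3 values shown sit. Among the measured steps, an at least 4.0-fold higher number from compound 2 to compound 3 (0.60 log units; beyond the scatter), whereas a step that the two limits leave unreadable from compound 1 to compound 3. Compound 4 `COC(=O)CC1CCN(C[C@H]2CN(c3ccc(-n4cc(-c5ccccn5)cn4)c(F)c3)C(=O)O2)CC1` differs from compound 3 by (methoxycarbonyl)methyl in place of hydrogen on a saturated ring carbon. Going by the values given here, no measured step adds a group onto the ring carbon itself, so compound 4 is expected to stay close to compound 3, an at least 1.1-fold lower number from compound 3 to compound 4 (0.05 log units; that floor lies within the scatter). Compound 4 is estimated at 350 ug/mL, between 150 ug/mL and 600 ug/mL.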

Compound 4, half-maximal inhibitory concentration: 224 ug/mL
For compound 4 the middle estimate is 1.6-fold (0.19 log units) above the measured one; low and high end bracket the measured number.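

In this assay, placing (methoxycarbonyl)methyl on this saturated ring carbon gives an at least 1.7-fold lower number from compound 3 to compound 4 (0.25 log units; that floor lies within the scatter), and changing the whole amine gives an at least 1.7-fold lower number from compound 1 to compound 4 (0.25 log units; that floor lies within the scatter). From the compounds shown here alone, both steps start from a limit of the assay rather than a number, so their full size stays unknown because of the ceiling: the limit of > 400 ug/mL in this assay, at which 2 of the 4 values shown sit. The step with both ends measured is a 2.3-fold higher number from compound 2 to compound 4 (0.35 log units; beyond the scatter), so this substituted piperidin-1-yl side chain can be compared directly with 4-ethylpiperazin-1-yl. Still open, going by these compounds, is how a carboxylic acid or an amine at the same ring carbon would read.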